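The source may hold more compounds than are shown below. What is called first, only, known or untested is meant among the compounds shown, and "the series" means these compounds.

In an ADME assay on HFF cells (Homo sapiens) for cytotoxicity, with a stated time of 8 days (a lower number here means that less compound is tolerated, a higher number that more compound is tolerated), compound 1 `Nc1nc(NC2CC2)c2ncn(/C=C3/CC3(CO)CO)c2n1` gives > 300000 nM, which is a limit and not a number. Compound 2 `CC(C)Sc1nc(N)nc2c1ncn2/C=C1/CC1(CO)CO` gives > 300000 nM, again only a limit. Compound 2 thus stands at the limit of > 300000 nM in this assay, at which 2 of the 2 values shown sit. Compound 3 `Nc1nc(SC2CCCC2)c2ncn(/C=C3/CC3(CO)CO)c2n1` differs from compound 2 by cyclopentyl in place of isopropyl on a sulfur, with cyclopentyl in place of isopropyl on a sulfur. Within the data shown here, the only measured step, a step that the two limits leave unreadable from compound 1 to compound 2, gives no size to carry over. No step beyond the scatter is therefore expected in this assay, though this expectation has no measured size behind it. The expected step is an at least 1.2-fold lower number from compound 2 to compound 3 (0.07 log units; that floor lies within the scatter). For compound 3 the estimate is 250000 nM, with an expected range from 100000 nM to 300000 nM.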

Compound 3, half-maximal cytotoxic concentration: > 300000 nM
Compound 3 gave a limit, no number (the forecaster's own chance of this, stated with the estimate: 70%); at least 1.2-fold (0.07 log units) between middle value and limit.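

Compound 1, compound 2 and compound 3 all stand at a limit, not a number, in this assay, so no step among them can be read: the limit of > 300000 nM in this assay, at which 3 of the 3 values shown sit.

On these data alone, whether cyclopentyl in place of isopropyl on a sulfur changes tolerated concentration stays open.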